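The source may hold more compounds than are shown below. What is called first, only, known or untested is meant among the compounds shown, and "the series" means these compounds.

Series notes. Compound 2 `COC(=O)/C=C1/C(=O)N2[C@@H]1SC(C)(C)[C@@H]2C(=O)OC(c1ccccc1)c1ccccc1` in a functional assay on A-375 cells (Homo sapiens) for cytotoxicity, read by MTT assay, with a stated time of 48 h (on this read-out lower numbers stand for stronger inhibition and higher numbers for weaker inhibition), gives 24600 nM. Compound 1 `CC1(C)S[C@@H]2/C(=C\C(=O)c3ccc(F)cc3)C(=O)N2[C@H]1C(=O)OC(c1ccccc1)c1ccccc1` gives 17800 nM in this assay, and the two values sit within the scatter of each other. For the measured compounds named here, the only measured step bearing on the next change is a 1.4-fold higher number from compound 1 to compound 2 (0.14 log units; within the scatter), which put methoxy in place of 4-fluorophenyl on a carbonyl carbon and stayed within the scatter. Compound 3 `CC1(C)S[C@@H]2/C(=C\C(=O)c3ccc4ccccc4c3)C(=O)N2[C@H]1C(=O)OC(c1ccccc1)c1ccccc1` differs from compound 2 by naphthalen-2-yl in place of methoxy on a carbonyl carbon. Because compound 1 with an aryl group on that carbonyl carbon gave 17800 nM, compound 3 is expected to land nearby, the expected step being a 1.9-fold lower number from compound 2 to compound 3 (0.28 log units; within the scatter). Compound 3 is estimated at 13000 nM, range 4500 nM to 38000 nM.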

Compound 3, half-maximal inhibitory concentration: 36500 nM
Estimate against measurement, compound 3: 2.8-fold (0.45 log units) below; low and high end bracket the measured number.
By their numbers in this assay, from the lowest: compounds 1, 2 and 3 (each within the scatter of the next, the first and the last beyond it).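

Working from this assay, the step of a 1.5-fold higher number from compound 2 to compound 3 (0.17 log units; within the scatter) leaves naphthalen-2-yl and methoxy on this carbonyl carbon unseparated, even though the entering group brings two aromatic rings and far more heavy atoms. For the compounds shown here, the exchange of one aryl group for another, a 2.1-fold higher number from compound 1 to compound 3 (0.31 log units; beyond the scatter), is the first step beyond the scatter, though only modestly, so the choice of aryl group can register at this position.

From the compounds shown here alone, how an amine, a plain phenyl or a longer alkyl chain on this carbonyl carbon would read remains open. No supporting data explain the difference between the two aryl groups.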